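The source may report more compounds than this note shows. Statements on the series, on what has been measured and on what is new or still open speak of the compounds shown alone.

Compound 1 `Clc1ccc(-c2cc(-c3ccsc3)nc(-c3ccccn3)c2)o1` was tested in a functional assay on DU-145 cells (Homo sapiens) for cytotoxicity, in the presence of a further agent that is not named here (on this read-out lower numbers stand for stronger inhibition and higher numbers for weaker inhibition), and gave 10900 nM. Compound 2 `Cc1ccc(-c2cc(-c3ccoc3)cc(-c3ccsc3)n2)cc1` gave 13000 nM in this assay, a value that lies within the scatter of the number for compound 1, so the two cannot be ranked. Compound 3 `Clc1ccc(-c2cc(-c3ccco3)cc(-c3cccs3)n2)cc1` reached only the limit of this assay, > 100000 nM, and that limit is the one described as the limit of > 100000 nM in this assay, at which 1 of the 3 values shown sits. Compound 4 `Clc1ccc(-c2cc(-c3ccsc3)nc(-c3ccco3)c2)o1` has not yet been measured in this assay. It differs from compound 1 by furan-2-yl in place of pyridin-2-yl on an aromatic carbon. Going by the values given here, no measured step of this kind is available, so the expected step is a modest move toward weaker inhibition, a 2.3-fold higher number from compound 1 to compound 4 (0.36 log units; beyond the scatter), and compound 4 is estimated at 25000 nM, between 8000 nM and 80000 nM.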

Compound 4, half-maximal inhibitory concentration: 18900 nM
Beside the measured number, compound 4's estimate is 1.3-fold (0.12 log units) above it; the measured number falls inside the stated range.
By their numbers in this assay, from the lowest: compounds 1, 2 and 4 (each within the scatter of the next). At a limit, above all of these: compound 3.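

Going by these compounds alone, this pair is the first comparison that differs in one place, and it shows that in this assay the position next to the ring nitrogen takes either a six-membered or a five-membered aromatic ring with one hetero atom. With a 1.7-fold higher number from compound 1 to compound 4 (0.24 log units; within the scatter) for this exchange, the two compounds cannot be ranked. Nothing at hand bears on a cause for this step.

From the compounds shown here alone, whether an amine or a carboxylic acid at this position would behave alike stays open. So does the effect of changing the thiophen-3-yl or 5-chlorofuran-2-yl groups, which this pair keeps fixed.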